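Acylaminothiadiazole series: extending the chloroacyl chain

A few compounds are considered here, and "the series" means these few. Any claim that something is new, unique, unknown or untested is made for them only; others in the source may bear on it.

Measured compounds:
compound 1 `COc1ccccc1C(=O)Nc1nnc(SCC(=O)Nc2ccc(Cl)cn2)s1` — > 80000 nM
compound 2 `O=C(CSc1nnc(NC(=O)CCl)s1)Nc1ccc(Cl)cn1` — 3600 nM

Among the measured compounds shown here, in a functional assay on HeLa cells (Homo sapiens) for antiproliferative activity, read by MTT assay, with a stated time of 48 h (on this read-out higher numbers stand for weaker inhibition and lower numbers for stronger inhibition), compound 2 gives 3600 nM, the only numerical value in the set. Compound 1 is reported only as a limit of the assay, > 80000 nM, so its position relative to compound 2 is known only by the minimum size of the step. For the measured compounds named here, that step, an at least 22-fold lower number from compound 1 to compound 2 (1.34 log units; beyond the scatter), is the one measured change and it sits on the carbonyl carbon of the acylamino group, the same region that is altered next.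

Compound 3 `O=C(CSc1nnc(NC(=O)CCCCl)s1)Nc1ccc(Cl)cn1` differs from compound 2 as 2-chloroethyl in place of chloro on a saturated chain carbon bound to a carbonyl carbon. Going by the values given here, the measured step concerned the whole group on the carbonyl carbon and was bounded by the limit of > 80000 nM in this assay, at which 1 of the 2 values shown sits; the present change is a smaller one, a lengthening of the chain within the chloroacyl group, and no measured pair speaks to chain length directly. The expected step is therefore a 4.2-fold higher number from compound 2 to compound 3 (0.62 log units; beyond the scatter), a moderate rise toward weaker inhibition, and the uncertainty around this expectation is wide. The estimate for compound 3 is 15000 nM, with a range from 4000 nM to 80000 nM.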

Compound 3, half-maximal inhibitory concentration: > 80000 nM
Compound 3 ended at the assay's limit; the forecaster's own chance of this, stated with the estimate: 30%; middle value at least 5.3-fold (0.72 log units) from the limit.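

Moving from chloromethyl to 3-chloropropyl on the carbonyl carbon gives an at least 22-fold higher number from compound 2 to compound 3 (1.34 log units; beyond the scatter), so chain length within the chloroacyl group matters at this position, something the earlier pair could not show, as it exchanged the whole group on the carbonyl carbon. Both compound 2 and compound 3 carry a chlorine on the acyl chain, so the presence of that chlorine alone is not enough to retain a measurable value in this assay. The step between compound 1 and compound 3 cannot be read, and compound 2 remains the only compound in the set with a numerical value: the limit of > 80000 nM in this assay, at which 2 of the 3 values shown sit.

Still open, from the compounds shown here alone, is how the value changes along the chain, and 2-chloroethyl on the carbonyl carbon would show whether the loss is gradual or abrupt. Also open, going by these compounds, is whether the chlorine of compound 2 is needed at all, a question that plain methyl on the carbonyl carbon would address directly against chloromethyl.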